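Shrinking the Amine Ring on a Urea Agonist

A few compounds are considered here, and "the series" means these few. Any claim that something is new, unique, unknown or untested is made for them only; others in the source may bear on it.

Three compounds of a shared core have been examined in an assay on CHO cells for agonist activity at transient receptor potential cation channel subfamily V member 1 (Homo sapiens); on this read-out lower numbers stand for an effect already at smaller amounts and higher numbers for an effect only at larger amounts of compound. Compound 1 `CC1CCN(c2nc(C(F)(F)F)ccc2CNC(=O)Nc2cccc3c(=O)[nH]ccc23)CC1` gives 9.59 nM and is the only one of the three with a number to its name. Compound 2 `CC1CCN(c2nc(C(F)(F)F)ccc2CNC(=O)Nc2cccc3cc[nH]c(=O)c23)CC1` gives "not active" (no number reported), and compound 3 `CC1CCN(c2nc(C(F)(F)F)ccc2CNC(=O)Nc2ccc3ccc(=O)[nH]c3c2)CC1` likewise gives "not active" (no number reported), so neither of these two offers a value that could be set beside that of compound 1. For the measured compounds named here, no single-point step between measured compounds is therefore available.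

Compound 4 `O=C(NCc1ccc(C(F)(F)F)nc1N1CCCC1)Nc1cccc2c(=O)[nH]ccc12` is the untested member of the set. It differs from compound 1 by pyrrolidin-1-yl in place of 4-methylpiperidin-1-yl on an aromatic carbon, the rest of the molecule being unchanged.

Going by the values given here, with no measured step to lean on, the direction and size of the change can only be judged from the structures. The smaller ring removes two heavy atoms from a part of the molecule that compound 1 carries as its sole numbered reference, so compound 4 is expected to show a modest loss in this assay, a step of a 3.1-fold higher number from compound 1 to compound 4 (0.50 log units; beyond the scatter) that may or may not exceed the scatter. Compound 4 is thus estimated at 30 nM, with a range from 8 nM to 120 nM.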

Compound 4, half-maximal effective concentration: 258 nM
For compound 4 the middle estimate is 8.6-fold (0.93 log units) below the measured one; the measured number lies above the stated range.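

In this assay, for the compounds shown here, the change from 4-methylpiperidin-1-yl to pyrrolidin-1-yl on the aromatic carbon next to the ring nitrogen gives a 27-fold higher number from compound 1 to compound 4 (1.43 log units; beyond the scatter) and provides the first measured step. It shows that the read-out depends strongly on the amine ring at this position, while compound 4 still gives a number, so an effect remains with the five-membered ring. The data shown offer no measured basis for explaining the size of this step.

The single step changes the ring size and removes the methyl group together, so the compounds shown cannot separate the contribution of either change; unsubstituted piperidin-1-yl would stand between compound 1 and compound 4 in structure, and its place in this order remains open. On these data alone, it is also open how this assay would respond to morpholin-4-yl, to azepan-1-yl or to an open-chain dimethylamino group at this position, and whether a longer substituent in place of the 4-methyl group would keep or change the value seen for compound 1.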